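Bromo to Fluoro on the Anilide of Compound 2

The source may report more compounds than this note shows. Statements on the series, on what has been measured and on what is new or still open speak of the compounds shown alone.

Measured compounds:
Compound 1, `COc1ccc(CNc2cc(OC)c(OC)c(OC)c2)cc1Br`: 29400 nM
Compound 2, `C/C=C/C(=O)N(Cc1ccc(OC)c(Br)c1)c1cc(OC)c(OC)c(OC)c1`: 6430 nM

Of the compounds shown here, two have been measured in a functional assay on MGC-803 cells (Homo sapiens) for inhibition, read by MTT assay, with a stated time of 48 h; on this read-out lower numbers stand for stronger inhibition and higher numbers for weaker inhibition. Compound 1 gives 29400 nM in this assay, and compound 2 gives 6430 nM. Within the data shown here, the only step known is a 4.6-fold lower number from compound 1 to compound 2 (0.66 log units; beyond the scatter), so compound 2 holds the lowest of the two numbers, with compound 1 as its nearest neighbour.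

Compound 3, `C/C=C/C(=O)N(Cc1ccc(OC)c(F)c1)c1cc(OC)c(OC)c(OC)c1`, has not yet been measured in this assay. It differs from compound 2 by fluoro in place of bromo on an aromatic carbon.

Among the measured compounds shown here, no measured step bears on this change: the single known step concerns the nitrogen on an aromatic ring, not the 3-bromo-4-methoxyphenyl group. For a change of one heavy atom to one heavy atom, with no change in ring count, donors, acceptors or charge, he expects a step no larger than the scatter, or at most a small one toward higher numbers, that is, toward weaker inhibition.

He therefore estimates compound 3 at 8500 nM in this assay, within 2500 nM to 28000 nM, which would mean an expected step of a 1.3-fold higher number from compound 2 to compound 3 (0.12 log units; within the scatter).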

Compound 3, half-maximal inhibitory concentration: 1650 nM
Compound 3: middle estimate off by 5.2-fold (0.71 log units), on the high side, and the stated range ends above it.
By their numbers in this assay, from the lowest: compound 3; then compound 2; then compound 1.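

In this assay the change from 3-bromo-4-methoxyphenyl to 3-fluoro-4-methoxyphenyl gives a 3.9-fold lower number from compound 2 to compound 3 (0.59 log units; beyond the scatter), so this aromatic carbon, ortho to a methoxy group, responds to the identity of a single halogen atom, although the heavy-atom count, the hydrogen-bond donors and acceptors and the net charge all stay the same. Among these compounds, the only earlier step, a 4.6-fold lower number from compound 1 to compound 2 (0.66 log units; beyond the scatter), concerned the nitrogen on an aromatic ring and said nothing about this side of the molecule, which now also carries a step beyond the scatter. The data given here hold nothing that accounts for the direction of this new step.

The compounds shown have only bromo and fluoro at this carbon, so it stays open whether a chloro group, a methyl group or plain hydrogen there would continue the trend or break it. Also open, as far as these compounds go, is whether the same swap would lower the number on the core of compound 1, which lacks the (prop-1-en-1-yl)carbonyl group, and whether an acetyl group or a longer chain on that nitrogen would keep the effect.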